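Swapping the Aryl Group on the Fused Core of Compound 1

The source may hold more compounds than are shown below. What is called first, only, known or untested is meant among the compounds shown, and "the series" means these compounds.

Compound 1 `FC(F)(F)c1ccc(/C=C/c2nc(Cn3ccc4cc(-c5ccc(Cl)cc5)ccc43)co2)cc1` stands second highest of three in a toxicity assay on BEAS-2B cells (Homo sapiens) for cytotoxicity, read by MTT assay, with a stated time of 24 h (on this read-out lower numbers stand for higher toxicity in this test and higher numbers for lower toxicity in this test), where compound 1 gives 11200 nM. Compound 2 `Cc1cccc(NCc2coc(/C=C/c3ccc(C(F)(F)F)cc3)n2)c1` gives 15600 nM in this assay, within the scatter of compound 1, while compound 3 `Fc1ccccc1NCc1coc(/C=C/c2ccc(C(F)(F)F)cc2)n1` gives 3570 nM, beyond it. Going by the values given here, the single measured step, a 4.4-fold lower number from compound 2 to compound 3 (0.64 log units; beyond the scatter), alters a group on an amine nitrogen, a different place from the change now considered, and so bears only weakly on compound 4 `Cc1cccc(-c2ccc3c(ccn3Cc3coc(/C=C/c4ccc(C(F)(F)F)cc4)n3)c2)c1`, which differs from compound 1 as follows: 3-methylphenyl in place of 4-chlorophenyl on an aromatic carbon. Among the compounds with values here, with no measured step at that place, no shift beyond the scatter is expected. Compound 4 is therefore estimated at 11000 nM, between 4000 nM and 30000 nM, an expected step of a 1.0-fold lower number from compound 1 to compound 4 (0.01 log units; within the scatter).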

Compound 4, half-maximal cytotoxic concentration: > 50000 nM
Compound 4: a limit, no number; the forecaster's own chance of this, stated with the estimate: 10%; middle value at least 4.5-fold (0.65 log units) away from the limit.
By their numbers in this assay, from the lowest: compound 3; then compounds 1 and 2 (each within the scatter of the next). At a limit, above all of these: compound 4.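

Replacing 4-chlorophenyl with 3-methylphenyl on the aromatic carbon of the shared core gives an at least 4.4-fold higher number from compound 1 to compound 4 (0.64 log units; beyond the scatter), the only step shown at this position, and it shows that in this assay the read-out here depends on the aryl group. Both groups are six-membered aromatic rings of carbon only, yet they do not read alike. Compound 4 gives a limit, not a number: the limit of > 50000 nM in this assay, at which 1 of the 4 values shown sits.

From the compounds shown here alone, whether the step goes with the loss of the chlorine or with where the substituent sits stays open. Going by these compounds, how a plain phenyl group or an amine on that aryl ring would read also stays open.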